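Replacing trifluoromethyl with trifluoromethoxy on a weak growth inhibitor

The source may report more compounds than this note shows. Statements on the series, on what has been measured and on what is new or still open speak of the compounds shown alone.

Compound 1 `Fc1ccc(-c2ccc(-c3ccc(-c4nc5ccccc5[nH]4)cc3)cc2)cc1` gives 29700 nM
Compound 2 `FC(F)(F)c1ccc(-c2ccc(-c3ccc(-c4nc5ccccc5[nH]4)cc3)cc2)cc1` gives 100000 nM

In a functional assay on SiHa cells (Homo sapiens) for inhibition, read by sulforhodamine B assay (a higher number here means a weaker inhibitor of growth, a lower number a stronger inhibitor of growth), compound 2 has the higher of the two numbers, so it is the weaker inhibitor of growth. Compound 3 `FC(F)(F)Oc1ccc(-c2ccc(-c3ccc(-c4nc5ccccc5[nH]4)cc3)cc2)cc1` carries trifluoromethoxy in place of trifluoromethyl on an aromatic carbon. Within the data shown here, only one measured step bears on this, the swap of fluoro for trifluoromethyl (a 3.4-fold higher number from compound 1 to compound 2 (0.53 log units; beyond the scatter)). Among the measured compounds shown here, it is modest, and no compound with trifluoromethoxy has been measured, so no step beyond the scatter is expected in this assay, with at most a slight drift toward a lower number. The expected step is small (a 1.4-fold lower number from compound 2 to compound 3 (0.15 log units; within the scatter)). Compound 3 is estimated at 70000 nM, within an expected range of 28000 nM to 140000 nM.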

Compound 3, concentration for 50% growth inhibition: 38400 nM
For compound 3 the middle estimate is 1.8-fold (0.26 log units) above the measured one; the measured number falls inside the stated range.
By their numbers in this assay, from the lowest: compounds 1 and 3 (each within the scatter of the next); then compound 2.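

In this assay trifluoromethoxy undoes the loss seen with trifluoromethyl, with a 2.6-fold lower number from compound 2 to compound 3 (0.42 log units; beyond the scatter), and a 1.3-fold higher number from compound 1 to compound 3 (0.11 log units; within the scatter) leaves it level with the fluoro compound. A bigger group on this aromatic carbon therefore does not by itself give a higher number, since trifluoromethoxy has more heavy atoms than trifluoromethyl. Nothing available explains why these two groups differ.

As far as these compounds go, all three groups here contain fluorine, so it remains open how a fluorine-free group, such as an amine, a carboxylic acid or a methoxy, would behave at this position.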